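A few compounds are considered here, and "the series" means these few. Any claim that something is new, unique, unknown or untested is made for them only; others in the source may bear on it.

Three compounds have numbers or a verdict in a functional assay on CAKI-1 cells (Homo sapiens) for inhibition; a lower number here means a stronger inhibitor of growth, a higher number a weaker inhibitor of growth. Compound 2, `COc1cc(/C=C/C(=O)c2cccc(-n3cc(-c4ccccc4)[nH]c3=O)c2)ccc1O`, gives 2190 nM in this assay. Among the compounds with values here, compound 3, `O=C(/C=C/c1cccc(O)c1)c1cccc(-n2cc(-c3ccccc3)[nH]c2=O)c1`, gives 13300 nM in this assay, and the change a 6.1-fold higher number from compound 2 to compound 3 (0.78 log units; beyond the scatter) is the only single-point step available. Compound 1, `COc1cc(/C=C/C(=O)c2cccc(-n3cc(-c4ccc(Cl)cc4)[nH]c3=O)c2)cc(OC)c1OC`, is reported in this assay as "not active" (no number reported), without a number. So compound 2 holds the lower of the two numbers, with compound 3 above it and compound 1 giving no number at all.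

Compound 4, `COc1ccc(-c2cn(-c3cccc(C(=O)/C=C/c4ccc(O)c(OC)c4)c3)c(=O)[nH]2)cc1`, is the compound still to be measured. It differs from compound 2 by methoxy in place of hydrogen on an aromatic carbon. That change sits on the aryl ring attached to the shared core, whereas the step from compound 2 to compound 3 alters the other end of the molecule, the aryl ring on the double-bonded chain. Within the data shown here, no measured pair isolates a change on the ring that carries the new methoxy group; compound 1 carries a different group there but also differs at the chain end, so it cannot be read as a step. Among the measured compounds shown here, with no direct precedent, compound 4 is expected to stay close to compound 2 in this assay, the step of a 1.3-fold higher number from compound 2 to compound 4 (0.11 log units; within the scatter) being an estimate that lies within the usual scatter. The estimated value for compound 4 in this assay is 2800 nM, with a range from 900 nM to 9000 nM.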

Compound 4, concentration for 50% growth inhibition: 4990 nM
Compound 4: the middle estimate sits 1.8-fold (0.25 log units) below what was measured; low and high end bracket the measured number.
By their numbers in this assay, from the lowest: compound 2; then compound 4; then compound 3.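

Changing phenyl to 4-methoxyphenyl gives, in this assay, a 2.3-fold higher number from compound 2 to compound 4 (0.36 log units; beyond the scatter). This is a modest weakening of growth inhibition, and it shows that the number responds to this aromatic ring and not only to the aryl ring on the double-bonded chain. Before this result, no measured pair isolated a change on this ring, and nothing available here bears on what lies behind the shift.

From the compounds shown here alone, this is still one group at one place, so it remains open whether chlorine alone on this ring would also weaken growth inhibition: compound 1 carries chlorine and is reported as "not active" (no number reported), but it differs at the chain end as well. Going by these compounds, it is equally open how a group of a different kind would behave on the same aromatic carbon, such as an amine or a carboxylic acid in place of the methoxy group.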